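Swapping the amine tail of a melanocortin-4 binder

A few compounds are considered here, and "the series" means these few. Any claim that something is new, unique, unknown or untested is made for them only; others in the source may bear on it.

Of the compounds shown here, three sharing one core have been measured so far in an assay for binding affinity to Melanocortin receptor 4 (Homo sapiens); on this read-out higher numbers stand for weaker inhibition and lower numbers for stronger inhibition. Compound 1 `CCCC/N=C(/N)NC(=O)c1cccc(F)c1CCc1cc(Br)ccc1OC` carries a butyl tail on the acylguanidine and gives 920 nM. Compound 2 `COc1ccc(Br)cc1CCc1c(F)cccc1C(=O)/N=C(\N)NCCCN1CCCCC1` instead ends its tail in a piperidin-1-yl group and gives 3.2 nM, the lowest number of the three and beyond the scatter from both others. Compound 3 `CCN(CC)CCCC(C)/N=C(\NC(=O)c1cccc(F)c1CCc1cc(Br)ccc1OC)Nc1ccccc1` differs from compound 2 in several places at once, and compound 3 gives 4100 nM. Within this small set, then, the compounds whose tail ends in a tertiary amine attached through a plain chain do better, with compound 3 standing against any simple reading of that idea.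

Compound 4 `COc1ccc(Br)cc1CCc1c(F)cccc1C(=O)/N=C(\N)NCCCCN(C)Cc1ccccc1` is the next compound to be tested. It differs from compound 2 in a single place: (benzyl(methyl)amino)methyl in place of piperidin-1-yl on a saturated chain carbon, three bonds along the chain from an amine nitrogen. Compound 4 keeps a tertiary amine at the end of the tail, so most of what made compound 2 strong is retained. Because compound 2 already sits at 3.2 nM, the step from compound 2 to compound 4 in this assay is expected to be a small loss, a 3.1-fold higher number from compound 2 to compound 4 (0.49 log units; beyond the scatter), possibly within the scatter. Compound 4 is therefore estimated at 10 nM, with a likely range from 2 nM to 60 nM.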

Compound 4, inhibition constant: 5.1 nM
Compound 4: the middle estimate sits 2.0-fold (0.29 log units) above what was measured; the measured number falls inside the stated range.
By their numbers in this assay, from the lowest: compounds 2 and 4 (each within the scatter of the next); then compound 1; then compound 3.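

Replacing piperidin-1-yl with (benzyl(methyl)amino)methyl, on a saturated chain carbon, three bonds along the chain from an amine nitrogen, gives in this assay a step of a 1.6-fold higher number from compound 2 to compound 4 (0.20 log units; within the scatter). This position therefore accepts a large change in shape on this read-out: a six-membered non-aromatic ring with 6 heavy atoms gives way to an open-chain group of 10 heavy atoms carrying a six-membered aromatic ring of carbon only, and the two compounds cannot be told apart. No measured evidence on hand bears on this result.

From the compounds shown here alone, whether the amine nitrogen itself is needed here stays open, and a carboxylic acid or a simple alcohol on the same chain carbon would be the direct test of that. Also open, going by these compounds, is how far the group can grow or change, for instance with a morpholine ring in place of piperidin-1-yl, or with a longer chain leading to the benzyl(methyl)amino group.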